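The source may hold more compounds than are shown below. What is called first, only, known or untested is meant among the compounds shown, and "the series" means these compounds.

Of the compounds shown here, two sharing one core have been measured in a functional assay (trachea) with Rattus norvegicus as the target; a lower number here means a less potent compound, a higher number a more potent compound, by a factor of ten per unit of this negative logarithm. Among the measured compounds shown here, compound 1, `CC1(C)C=C(n2ccccc2=O)c2cc(C=O)ccc2O1`, is the first of them; in this assay compound 1 gives 6.14. Compound 2, `CC1(C)C=C(n2ccccc2=O)c2cc(OC(=O)Nc3ccc(F)cc3)ccc2O1`, carries a (4-fluorophenyl)carbamoyl on an oxygen on an aromatic ring; in this assay compound 2 gives 4.37. That places compound 2 at the lower of the two numbers, with compound 1 standing higher by a gap that lies beyond the scatter of the method.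

Compound 3, `CC1(C)C=C(n2ccccc2=O)c2cc(OS(=O)(=O)F)ccc2O1`, has not yet been measured. It differs from compound 2 in one place: fluorosulfonyl in place of (4-fluorophenyl)carbamoyl on an oxygen on an aromatic ring. For the measured compounds named here, no pair of measured compounds shows this change, so its effect can only be judged from the two values known. The group that enters is counted as much smaller than the group that leaves, and compound 1, which carries no such large group, stands well above compound 2. On that basis compound 3 is expected to gain, by an estimated step of a number 0.63 log units higher from compound 2 to compound 3 (beyond the scatter), upward but uncertain. Compound 3 is therefore estimated at 5, within a range from 4 to 6.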

Compound 3, logarithm of the reciprocal of the active concentration, log(1/C): 7.22
Compound 3: middle estimate off by 2.22 log units, on the low side, outside the stated range (above it).
By their numbers in this assay, from the lowest: compound 2; then compound 1; then compound 3.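

In this assay, putting fluorosulfonyl in place of (4-fluorophenyl)carbamoyl on the oxygen on an aromatic ring gives a number 2.85 log units higher from compound 2 to compound 3 (beyond the scatter), so a substituent at this place can go with a far higher number than compound 2 alone suggested. The second comparison adds something the first two compounds could not show: with (fluorosulfonyl)oxy in place of formyl on the aromatic carbon, the result is a number 1.08 log units higher from compound 1 to compound 3 (beyond the scatter), so formyl no longer marks the top of this short series, and the smaller substituent of compound 3 does more than merely return the number to the level of compound 1. No measurement is available here that explains this order of the groups.

The compounds shown leave open whether the high number belongs specifically to fluorosulfonyl or is shared by other small groups on the same oxygen, such as methylsulfonyl or acetyl. They also leave open where a free hydroxyl or an amine at this aromatic carbon would stand relative to compound 1 and compound 3.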